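Nitro for Hydrogen on the Methoxy-Bearing Ring

The source may hold more compounds than are shown below. What is called first, only, known or untested is meant among the compounds shown, and "the series" means these compounds.

Measured compounds:
- compound 1, `COc1ccc(Cn2cc(CNC(=O)c3ccc([N+](=O)[O-])o3)nn2)cc1F`, 312000 nM
- compound 2, `COc1ccc(Cn2cc(CNC(=O)c3ccc([N+](=O)[O-])o3)nn2)cc1`, 274000 nM

In an ADME assay on Vero cells (Chlorocebus sabaeus) for cytotoxicity (a higher number here means a weaker inhibitor, a lower number a stronger inhibitor), compound 2 gives 274000 nM, and compound 1 gives 312000 nM. The two numbers lie within the scatter of each other, so compound 2 cannot be told apart from compound 1 on this measure.

Compound 3, `COc1ccc(Cn2cc(CNC(=O)c3ccc([N+](=O)[O-])o3)nn2)cc1[N+](=O)[O-]`, differs from compound 2 in one place: nitro in place of hydrogen on an aromatic carbon. Within the data shown here, the one measured step that touches this position is a 1.1-fold lower number from compound 1 to compound 2 (0.06 log units; within the scatter), in which a fluoro at the same aromatic carbon was swapped for hydrogen without leaving the scatter. Among the measured compounds shown here, that step is the only guide available, and it covers a smaller group than nitro, so the guidance is thin. On that basis the step from compound 2 to compound 3 is expected to stay within the scatter, a 1.0-fold higher number from compound 2 to compound 3 (0.01 log units; within the scatter). The estimated value for compound 3 in this assay is 280000 nM, with a range from 120000 nM to 600000 nM.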

Compound 3, half-maximal inhibitory concentration: 176000 nM
Compound 3: the middle estimate sits 1.6-fold (0.20 log units) above what was measured; low and high end bracket the measured number.
By their numbers in this assay, from the lowest: compounds 3, 2 and 1 (each within the scatter of the next).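

With compound 3, this aromatic carbon, ortho to a methoxy group, has now carried hydrogen, fluoro and nitro, and in this assay no swap among the three leaves the scatter. The earlier compounds shown here tested only fluoro against hydrogen, whereas nitro brings 3 heavy atoms, including 2 hydrogen-bond acceptors, and still the readings stay within the scatter, both for the change from hydrogen (a 1.6-fold lower number from compound 2 to compound 3 (0.19 log units; within the scatter)) and for the change from fluoro (a 1.8-fold lower number from compound 1 to compound 3 (0.25 log units; within the scatter)). The three compounds therefore cannot be put in order on this measure, and nothing shown explains why the position tolerates such different groups in this assay.

On these data alone, these three compounds cover only hydrogen, fluoro and nitro at this carbon, so it remains open whether an amine, a carboxylic acid or a longer chain such as butoxy would also stay within the scatter. As far as these compounds go, it is also open whether the same holds at the other carbons of this ring, or with a group other than methoxy alongside the changing position.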